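Changing the anilino substituent: expected effect on cell inhibition

A few compounds are considered here, and "the series" means these few. Any claim that something is new, unique, unknown or untested is made for them only; others in the source may bear on it.

Measured so far:
- compound 1 `COc1cc(NC(=O)Nc2cc(Nc3ccc(C)c(C)c3)ncn2)cc(OC)c1`: 29.5%
- compound 2 `COc1ccc(Nc2cc(NC(=O)Nc3c(Cl)cccc3Cl)ncn2)cc1C`: 29.1%
- compound 3 `COc1cc(Nc2cc(NC(=O)Nc3c(Cl)cccc3Cl)ncn2)cc(C(F)(F)F)c1`: 23.1%

In a functional assay on NCI-H520 cells (Homo sapiens) for inhibition, read by MTT assay, with a stated time of 48 h, tested at 10 uM (a higher number here means more inhibition at the concentration tested (going by the name of the read-out), a lower number less inhibition), compound 1 shows the highest of these three numbers, yet its gaps to compound 2 and to compound 3 both lie within the usual scatter, so the three effectively stand level. Compound 4 `COc1cc(NC(=O)Nc2cc(Nc3cc(Br)ccc3OC)ncn2)cc(OC)c1` has not been measured yet. It differs from compound 1 in a single place: 5-bromo-2-methoxyphenyl in place of 3,4-dimethylphenyl on a nitrogen on an aromatic ring. Within the data shown here, no two measured compounds differ in only one place, so no measured step shows how large such a change can be. With all three known values clustered closely and the rest of the molecule unchanged, a step of no more than the scatter is expected in this assay, in either direction. Compound 4 is therefore estimated at 27%, within 10% to 45%, which corresponds to an expected step of a number 2.5 percentage points lower from compound 1 to compound 4 (within the scatter).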

Compound 4, a percentage reported as inhibition, at one concentration (the size of the read-out at that concentration, not a potency): 43.5%
Estimate against measurement, compound 4: 16.5 percentage points below; low and high end bracket the measured number.
By their numbers in this assay, from the lowest: compounds 3, 2 and 1 (each within the scatter of the next); then compound 4.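

In this assay, replacing 3,4-dimethylphenyl with 5-bromo-2-methoxyphenyl on the nitrogen gives a number 14 percentage points higher from compound 1 to compound 4 (beyond the scatter) as the first single-place change shown here. Among these compounds, it shows that this position can alter the number by more than the usual scatter, and that this swap raises it in the one pair available. No supporting measurement explains the rise. Open, from the compounds shown here alone, is whether the bromine, the methoxy or the two together account for the step, and how a ring carrying an amine or a carboxylic acid would behave here.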